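A Methoxycarbonyl Swap in a Cell Toxicity Test

This account rests on a few compounds, and the source may have more. Where it says the series, first, only, none or still open, it means among the compounds named here.

Toxicity to human cells is followed here in an ADME assay on TZM cells (Homo sapiens) for cytotoxicity, read by XTT assay, with a stated time of 4 days; on this read-out lower numbers stand for higher toxicity in this test and higher numbers for lower toxicity in this test. Compound 1 `Cc1cc(CCC#N)cc(C)c1Oc1cc(Nc2ccc(C#N)cc2)c(N)cc1C(=O)O` carries a carboxy group on the shared core, and in this assay compound 1 gives 14300 nM. Compound 2 `Cc1cc(CCC#N)cc(C)c1Oc1cc(Nc2ccc(C#N)cc2)c(N)cc1CO` has hydroxymethyl in place of carboxy on an aromatic carbon. Compound 2 reads > 23800 nM, which is a limit of the assay and not a number, so its standing is known only as that limit (the limit of > 23800 nM in this assay, at which 1 of the 2 values shown sits).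

The next structure is compound 3 `COC(=O)c1cc(N)c(Nc2ccc(C#N)cc2)cc1Oc1c(C)cc(CCC#N)cc1C`, with methoxycarbonyl in place of hydroxymethyl on an aromatic carbon.

Going by the values given here, the only measured step that bears on this swap is an at least 1.6-fold higher number from compound 1 to compound 2 (0.22 log units; that floor lies within the scatter), so no step beyond the scatter is expected in this assay. The estimated step is an at least 1.3-fold lower number from compound 2 to compound 3 (0.12 log units; that floor lies within the scatter). This estimate is loose, since it rests on a single step whose far end is a limit. For compound 3 the estimated value is 18000 nM, with an expected range of 7000 nM to 40000 nM.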

Compound 3, half-maximal cytotoxic concentration: > 22700 nM
Compound 3: no number, only a limit; the forecaster's own chance of this, stated with the estimate: 35%; at least 1.2-fold (0.10 log units) between middle value and limit.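

In this assay compound 3 gives > 22700 nM, which is a limit of the assay and not a number, so a second group at this position, ortho to a large group and para to a (4-cyanophenyl)amino group, reaches a limit rather than a measured value. Turning the carboxy group into methoxycarbonyl, with methyl in place of hydrogen on the oxygen, gives an at least 1.5-fold higher number from compound 1 to compound 3 (0.20 log units; that floor lies within the scatter), and since that floor lies within the scatter, this step alone does not establish a real difference from the acid. Among these three compounds only compound 1, with its carboxy group, gives a number, while methoxycarbonyl with no hydrogen-bond donor and hydroxymethyl with one both end at limits, and the step between compound 2 and compound 3 cannot be read.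

Going by these compounds, the true values of compound 2 and compound 3 remain unknown, so neither can yet be ranked against the other or firmly set apart from compound 1. On these data alone, whether a carboxamide or an aminomethyl group on this aromatic carbon would give a number, as compound 1 does, or a limit, as compound 2 and compound 3 do, also stays open.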